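Swapping Bromo for Methyl: Expected Effect on Cytotoxicity

This account rests on a few compounds, and the source may have more. Where it says the series, first, only, none or still open, it means among the compounds named here.

Measured so far:
compound 1, `NS(=O)(=O)c1ccc(N2N=C(c3ccc(O)cc3)CC2c2cn(-c3ccccc3)nc2-c2ccccc2)cc1`: > 160000 nM
compound 2, `NS(=O)(=O)c1ccc(N2N=C(c3ccc(Br)cc3)CC2c2cn(-c3ccccc3)nc2-c2ccc(F)cc2)cc1`: 49400 nM

Of the compounds shown here, two sharing one core have been tested in an ADME assay on Vero cells (Chlorocebus sabaeus) for cytotoxicity, read by MTT assay, with a stated time of 72 h; on this read-out lower numbers stand for higher toxicity in this test and higher numbers for lower toxicity in this test. For compound 1 the entry > 160000 nM is a limit of the test, not a measured number. Compound 2 gives 49400 nM in this assay. Going by the values given here, that makes compound 2 the holder of the only actual number in this set; the other entry is a limit, as noted in the limit of > 160000 nM in this assay, at which 1 of the 2 values shown sits. Among the compounds with values here, no pair of measured compounds differs in a single place, so no measured step shows how a small change on the outer ring moves the read-out.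

Compound 3, `Cc1ccc(C2=NN(c3ccc(S(N)(=O)=O)cc3)C(c3cn(-c4ccccc4)nc3-c3ccc(F)cc3)C2)cc1`, is not yet measured. It differs from compound 2 by methyl in place of bromo on an aromatic carbon. Within the data shown here, with no measured step to lean on, the expected change is a 1.2-fold higher number from compound 2 to compound 3 (0.08 log units; within the scatter), lying within the usual scatter and pointing in no clear direction. Compound 3 is therefore estimated at 60000 nM, with a plausible range from 25000 nM to 160000 nM.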

Compound 3, half-maximal cytotoxic concentration: > 90600 nM
Compound 3 was reported as a limit; the forecaster's own chance of this, stated with the estimate: 20%; middle value at least 1.5-fold (0.17 log units) away from the limit.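

Going by these compounds alone, compound 3 supplies the first change in this set made at a single place, on an aromatic carbon of a six-membered aromatic ring of carbon only, para to a large group. In this assay compound 3 gives > 90600 nM, which is a limit of the test and not a measured number. Putting methyl where bromo stood gives an at least 1.8-fold higher number from compound 2 to compound 3 (0.26 log units; that floor lies within the scatter), so this swap shows no sign of raising toxicity in this test, while the true size of the step remains unknown: the limit of > 90600 nM in this assay, at which 1 of the 3 values shown sits.

The compounds shown leave open how far the true value of compound 3 lies from that floor, and compound 1 cannot help settle it, as it differs from compound 2 in more than one place and also carries only a limit: the limit of > 160000 nM in this assay, at which 1 of the 3 values shown sits.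

They also leave open what an amine, a carboxylic acid or a longer chain such as propyl would do at this same ring position, where only bromo and methyl can be compared so far.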